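A few compounds are considered here, and "the series" means these few. Any claim that something is new, unique, unknown or untested is made for them only; others in the source may bear on it.

Compound 1 `C/C=C/C(=O)Nc1cc2c(N3CCc4ccccc43)ncnc2cc1OC`: 8120 nM
Compound 2 `CC/C=C/C(=O)Nc1cc2c(N3CCc4ccccc43)ncnc2cc1OC`: 5890 nM
Compound 3 `COc1cc2ncnc(N3CCc4ccccc43)c2cc1NC(=O)/C=C/C(C)C`: 6530 nM

All three numbers come from a functional assay on PC-3 cells (Homo sapiens) for antiproliferative activity, read by MTT assay, with a stated time of 72 h; on this read-out higher numbers stand for weaker inhibition and lower numbers for stronger inhibition. Compound 2 shows the lowest number of the three, yet the spread is within the scatter: a 1.4-fold lower number from compound 1 to compound 2 (0.14 log units; within the scatter) and a 1.1-fold higher number from compound 2 to compound 3 (0.04 log units; within the scatter). Compound 4 `CC/C=C/C(=O)Nc1cc2c(N3CCc4ccccc43)ncnc2cc1O[C@@H]1CCOC1` is built from compound 2 by a change at a different place: oxolan-3-yl in place of methyl on an oxygen on an aromatic ring. The measured steps all alter the chain on the amide, and the third, a 1.2-fold lower number from compound 1 to compound 3 (0.09 log units; within the scatter), is likewise small; none touches the oxygen on the aromatic ring, so none bears directly on this change. Among the compounds with values here, with no guiding step, no move beyond the scatter is expected, so a 1.3-fold lower number from compound 2 to compound 4 (0.12 log units; within the scatter) is the estimated step. Compound 4 is therefore expected to give about 4500 nM, between 1500 nM and 14000 nM.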

Compound 4, half-maximal inhibitory concentration: 9590 nM
Compound 4: the middle estimate sits 2.1-fold (0.33 log units) below what was measured; measured number inside the range.
By their numbers in this assay, from the lowest: compounds 2, 3, 1 and 4 (each within the scatter of the next).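

Compound 4 carries oxolan-3-yl, a five-membered ring of 5 heavy atoms with a defined stereocentre, in place of methyl on the oxygen on the aromatic ring. In this assay, within the data shown here, the swap gives a 1.6-fold higher number from compound 2 to compound 4 (0.21 log units; within the scatter) and, unlike the earlier steps on the amide chain, it shows that this oxygen can carry the larger group without a move beyond the scatter. Nothing measured here accounts for the step. From the compounds shown here alone, it remains open whether a longer chain ending in an amine would behave the same way on this oxygen, and whether the opposite stereocentre of oxolan-3-yl would match.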